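A few compounds are considered here, and "the series" means these few. Any claim that something is new, unique, unknown or untested is made for them only; others in the source may bear on it.

Among the compounds with values here, compound 1, `COc1cccc(-c2nc(SC)nc3sc(C(=O)NCc4ccccc4)c(N)c23)c1`, is one of two compounds measured in a functional assay on HEK293 cells for agonist activity at lutropin-choriogonadotropic hormone receptor (Homo sapiens), read by cAMP accumulation; a lower number here means a smaller maximal response, a higher number a larger maximal response. In this assay compound 1 gives 7.8%, the larger of the two numbers shown, although the gap to the other compound lies within the usual scatter. That other compound, compound 2, `CCOC(=O)c1sc2nc(SC)nc(-c3cccc(OC)c3)c2c1N`, gives 4.2%. Within the data shown here, the single measured step, a number 3.6 percentage points lower from compound 1 to compound 2 (within the scatter), alters the group on the carbonyl carbon and stays within the scatter.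

Compound 3, `COc1cccc(-c2nc(SC)nc3sc(C(=O)N(C)C)c(N)c23)c1`, has not yet been measured. It differs from compound 1 in one place: dimethylamino in place of benzylamino on a carbonyl carbon. Among the measured compounds shown here, the one measured step that bears on this change is a number 3.6 percentage points lower from compound 1 to compound 2 (within the scatter), which also removed the benzylamino group from the carbonyl carbon and produced no movement beyond the scatter. On that basis no step beyond the scatter is expected here either, and the estimated step is a number 1.8 percentage points lower from compound 1 to compound 3 (within the scatter). Compound 3 is therefore expected to give about 6% in this assay, with a range from 0% to 18%.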

Compound 3, largest response reached (reported as efficacy), in percent of the reference or control that the assay uses: 11%
Compound 3: middle estimate off by 5 percentage points, on the low side; low and high end bracket the measured number.
By their numbers in this assay, from the lowest: compounds 2, 1 and 3 (each within the scatter of the next).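

In this assay, putting dimethylamino in place of benzylamino on the carbonyl carbon gives a number 3.2 percentage points higher from compound 1 to compound 3 (within the scatter), so the benzylamino group's six-membered aromatic ring and the amide hydrogen can both leave this position without a movement beyond the scatter. The second new comparison, dimethylamino in place of ethoxy, gives a number 6.8 percentage points higher from compound 2 to compound 3 (within the scatter) and also stays within the scatter, so the benzylamino, ethoxy and dimethylamino groups are not separated from one another by any of the three steps now available at this position. Nothing measured here offers an explanation for these small differences.

The compounds shown leave open whether any other group on this carbonyl carbon, such as a hydroxyl group completing a carboxylic acid or a piperidine ring attached through its nitrogen, would move the maximal response beyond the scatter. All three compounds also share the rest of the core, so they leave open how much of the response depends on the methylthio group or the methoxyphenyl group, which stay the same throughout.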